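The source may report more compounds than this note shows. Statements on the series, on what has been measured and on what is new or still open speak of the compounds shown alone.

Measured so far in an assay on microsomes from liver for inhibition of 3-hydroxy-3-methylglutaryl-coenzyme A reductase (Rattus norvegicus); on this read-out lower numbers stand for stronger inhibition and higher numbers for weaker inhibition:
compound 1 `CC(C)c1c(C(=O)NCc2cccc(F)c2F)nn(-c2ccc(F)cc2)c1OC[C@@H](O)C[C@@H](O)CC(=O)O` gives 2 nM
compound 2 `CC(C)c1c(C(=O)N2CCCCC2)nn(-c2ccc(F)cc2)c1OC[C@@H](O)C[C@@H](O)CC(=O)O` gives 47 nM

Among the compounds with values here, compound 2 stands highest of the two numbers in this assay; its only neighbour, compound 1, sits far below it, as the step of a 24-fold higher number from compound 1 to compound 2 (1.37 log units; beyond the scatter) shows. The next compound, compound 3 `CC(C)c1c(C(=O)NCc2ccccn2)nn(-c2ccc(F)cc2)c1OC[C@@H](O)C[C@@H](O)CC(=O)O`, differs from compound 2 in one place: ((pyridin-2-yl)methyl)amino in place of piperidin-1-yl on a carbonyl carbon. Within the data shown here, the one measured step that bears on this change is a 24-fold higher number from compound 1 to compound 2 (1.37 log units; beyond the scatter), in which (2,3-difluorobenzyl)amino was exchanged for piperidin-1-yl on the same carbonyl carbon. Compound 3 brings back an amino group carrying a ring-bearing methyl, here ((pyridin-2-yl)methyl)amino, so a large part of that step is expected to be undone in this assay, giving a lower number for compound 3 than for compound 2. Compound 3 is therefore expected to give 5 nM, within a range of 2 nM to 20 nM. That corresponds to an expected step of a 9.4-fold lower number from compound 2 to compound 3 (0.97 log units; beyond the scatter).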

Compound 3, half-maximal inhibitory concentration: 25 nM
Compound 3: middle estimate off by 5.0-fold (0.70 log units), on the low side, outside the stated range (above it).
By their numbers in this assay, from the lowest: compound 1; then compounds 3 and 2 (each within the scatter of the next).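

In this assay, restoring the amide hydrogen and a ring-bearing methyl does not by itself recover the strength of compound 1: ((pyridin-2-yl)methyl)amino in place of piperidin-1-yl on the carbonyl carbon gives a 1.9-fold lower number from compound 2 to compound 3 (0.27 log units; within the scatter), so these two compounds cannot be told apart. The ring on the saturated chain carbon matters instead, since pyridin-2-yl in place of 2,3-difluorophenyl gives a 13-fold higher number from compound 1 to compound 3 (1.10 log units; beyond the scatter), a large step with the amide and its methyl unchanged. Nothing measured on these compounds accounts for either step.

Going by these compounds, it remains open whether that large step follows the ring nitrogen or the two fluorines; an unsubstituted benzyl or a monofluorobenzyl group would separate them. Also open, on these data alone, is how pyridin-3-yl, pyridin-4-yl or a longer chain before the ring would read.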